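Cyano in place of bromo: expected tolerance for compound 3

The source may report more compounds than this note shows. Statements on the series, on what has been measured and on what is new or still open speak of the compounds shown alone.

Compound 2 `O=C(CCCOc1ccccc1)Nc1ncc(Br)s1` stands at the lowest of the two numbers gathered so far. In an ADME assay on HepG2 cells (Homo sapiens) for cytotoxicity, read by CellTiter-Glo, with a stated time of 48 h (a lower number here means that less compound is tolerated, a higher number that more compound is tolerated), compound 2 gives 1600 nM; its nearest neighbour, compound 1 `Cc1cc(OCCCC(=O)Nc2ncc(Br)s2)ccc1Cl`, gives 4000 nM, a gap beyond the usual scatter. Compound 3 `N#Cc1cnc(NC(=O)CCCOc2ccccc2)s1` is still to be measured in this assay. It differs from compound 2 by cyano in place of bromo on an aromatic carbon. Going by the values given here, no step between measured compounds covers this change, so the step expected is a 1.3-fold higher number from compound 2 to compound 3 (0.10 log units; within the scatter), small and likely within the scatter, with no firm direction. Compound 3 is therefore estimated at 2000 nM, with a range from 700 nM to 6000 nM.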

Compound 3, half-maximal cytotoxic concentration: 4000 nM
Compound 3: the middle estimate sits 2.0-fold (0.30 log units) below what was measured; the range from low to high includes it.
By their numbers in this assay, from the lowest: compound 2; then compounds 1 and 3 (each within the scatter of the next).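

Cyano in place of bromo next to the ring sulfur gives a 2.5-fold higher number from compound 2 to compound 3 (0.40 log units; beyond the scatter) in this assay and shows that this position is not indifferent to the group it carries. The bromo is not needed for the tolerance of compound 2, since compound 3 carries no halogen and gives the higher number. Nothing at hand accounts for this step.

Going by these compounds, whether an amine or a carboxylic acid at this position would shift the number further stays open. So does whether the step holds on the core of compound 1.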